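The source may hold more compounds than are shown below. What is called first, only, known or untested is meant among the compounds shown, and "the series" means these compounds.

Compound 2 `Cc1noc(C)c1-c1cnc(N)c(Oc2ccc(C(=O)Nc3ccccc3Cl)cc2)n1` carries a 2-chlorophenyl on an amide-type nitrogen. In a functional assay on U-87MG ATCC cells for inhibition, with U-87 MG (Homo sapiens) as the target, read by MTT assay, with a stated time of 72 h (on this read-out higher numbers stand for weaker inhibition and lower numbers for stronger inhibition), compound 2 gives 60500 nM, the highest of the two numbers available, and its nearest neighbour is compound 1 `Cc1noc(C)c1-c1cnc(N)c(Oc2ccc(C(=O)NC3CCCCC3)cc2)n1`, which in this assay gives 40400 nM. Within the data shown here, the only step among the measured compounds, a 1.5-fold higher number from compound 1 to compound 2 (0.18 log units; within the scatter), lies within the scatter. Compound 3 `Cc1noc(C)c1-c1cnc(N)c(Oc2ccc(C(=O)Nc3ccc(Cl)cn3)cc2)n1` has not yet been measured in this assay. It differs from compound 2 in one place: 5-chloropyridin-2-yl in place of 2-chlorophenyl on an amide-type nitrogen. Among the measured compounds shown here, no measured step exchanges a carbon-only aromatic ring for a ring with one hetero atom on this nitrogen, so the closest guide is the step from compound 1 to compound 2, which replaced a cyclohexyl by a 2-chlorophenyl at the same place and stayed within the scatter. On that basis no step beyond the scatter is expected in this assay, the estimated step being a 1.1-fold lower number from compound 2 to compound 3 (0.04 log units; within the scatter). Compound 3 is therefore expected to give about 55000 nM in this assay, with a range from 20000 nM to 150000 nM.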

Compound 3, half-maximal inhibitory concentration: 45600 nM
For compound 3 the middle estimate is 1.2-fold (0.08 log units) above the measured one; low and high end bracket the measured number.
By their numbers in this assay, from the lowest: compounds 1, 3 and 2 (each within the scatter of the next).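

In this assay, the step from 2-chlorophenyl to 5-chloropyridin-2-yl on the amide-type nitrogen is a 1.3-fold lower number from compound 2 to compound 3 (0.12 log units; within the scatter), so placing a ring with one hetero atom and one hydrogen-bond acceptor here, in place of a carbon-only aromatic ring, gives no change that can be read. Measured against cyclohexyl at the same place, the 5-chloropyridin-2-yl group gives a 1.1-fold higher number from compound 1 to compound 3 (0.05 log units; within the scatter), so the three groups on this nitrogen, one of them not aromatic, cannot be told apart in this assay. Nothing available bears on why these groups give such similar numbers.

The compounds shown leave open whether any group on this nitrogen can shift the number beyond the scatter, for instance a carboxylic acid, an amine or a longer alkyl chain in place of the ring. They also leave open what an unsubstituted phenyl or pyridin-2-yl would give, and so whether the chlorine matters at all in either ring.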